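The source may report more compounds than this note shows. Statements on the series, on what has been measured and on what is new or still open speak of the compounds shown alone.

The measured compounds:
- compound 1 `Cc1ccccc1C(=O)Nc1cccc(/C=C/C(=O)c2nc3ccccc3[nH]2)c1`, which in a functional assay on HCT-116 cells (Homo sapiens) for antiproliferative activity, read by MTT assay, with a stated time of 48 h (a lower number here means a stronger inhibitor, a higher number a weaker inhibitor), gives 1870 nM;
- compound 2 `O=C(/C=C/c1cccc(NS(=O)(=O)c2ccc(Cl)cc2)c1)c1nc2ccccc2[nH]1`, which in this assay gives 1960 nM.

Within the data shown here, compound 2 holds the higher of these two numbers, but its only neighbour, compound 1, lies within the scatter of it, so the two cannot be told apart. Compound 3 `Cc1ccccc1S(=O)(=O)Nc1cccc(/C=C/C(=O)c2nc3ccccc3[nH]2)c1` has not been measured. It differs from compound 2 by 2-methylphenyl in place of 4-chlorophenyl on a sulfonyl sulfur. Among the measured compounds shown here, one measured step bears on this: a 1.0-fold higher number from compound 1 to compound 2 (0.02 log units; within the scatter). That step changed the ring and the group on the nitrogen together, and the number hardly moved. The change to compound 3 keeps the sulfonyl of compound 2 and brings back the 2-methylphenyl ring of compound 1, so it combines parts of two compounds whose numbers sit within the scatter of each other. No step beyond the scatter is therefore expected in this assay, in either direction. For compound 3 the estimate is 2000 nM, with a range from 800 nM to 5000 nM. The expected step is a 1.0-fold higher number from compound 2 to compound 3 (0.01 log units; within the scatter).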

Compound 3, half-maximal inhibitory concentration: 955 nM
Estimate against measurement, compound 3: 2.1-fold (0.32 log units) above; the range from low to high includes it.
By their numbers in this assay, from the lowest: compounds 3, 1 and 2 (each within the scatter of the next, the first and the last beyond it).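

On the sulfonyl sulfur, the aromatic ring alone can move the number in this assay: replacing 4-chlorophenyl with 2-methylphenyl gives a 2.1-fold lower number from compound 2 to compound 3 (0.31 log units; beyond the scatter), a modest step but the first here beyond the scatter. With the 2-methylphenyl ring held constant, replacing the carbonyl with a sulfonyl gives a 2.0-fold lower number from compound 1 to compound 3 (0.29 log units; within the scatter), so this link on the nitrogen has no effect that can be told from the scatter. No measurement here accounts for the ring step.

The swap removes a chlorine and adds a methyl in one move, so the compounds shown cannot say which of the two matters, or whether the ring's substitution position does. Also open, going by these compounds, is how this position would respond to a ring bearing an amine or a carboxylic acid.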